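The source may hold more compounds than are shown below. What is called first, only, known or untested is meant among the compounds shown, and "the series" means these compounds.

Measured so far:
compound 1, `NC(=S)N/N=C/c1ccc2ccccc2n1`: 960 nM
compound 2, `NC(=S)N/N=C/c1nc2ccccc2s1`: 5350 nM
compound 3, `NC(=S)N/N=C/c1cnc2ccccc2n1`: a limit only

In a functional assay on HeLa cells (Homo sapiens) for antiproliferative activity, read by sulforhodamine B assay, with a stated time of 72 h (a higher number here means a weaker inhibitor, a lower number a stronger inhibitor), compound 1 gives 960 nM, the lowest of the two numbers in hand. Compound 2 gives 5350 nM, a gap beyond the scatter. Compound 3 returns only a limit, > 100000 nM, so no number is known for it; this is the case of the limit of > 100000 nM in this assay, at which 1 of the 3 values shown sits.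

Compound 4, `Fc1ccc(NC(=S)N/N=C/c2ccc3ccccc3n2)cc1`, is the next member. It differs from compound 1 by 4-fluorophenyl in place of hydrogen on an amide-type nitrogen. Going by the values given here, no pair of measured compounds covers a change of this kind, so nothing measured here sets its size or direction. The shared core of compound 1 is kept unchanged, and compound 1 already sits at the low end of the series in this assay. The expectation for compound 4 is therefore a step of a 1.6-fold lower number from compound 1 to compound 4 (0.20 log units; within the scatter), that is a small move, not clearly beyond the scatter, and with no strong reason to expect a loss. Compound 4 is estimated at 600 nM in this assay, with a range from 120 nM to 3000 nM.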

Compound 4, half-maximal inhibitory concentration: 33200 nM
Compound 4: middle estimate off by 55-fold (1.74 log units), on the low side; the measured number lies above the stated range.
By their numbers in this assay, from the lowest: compound 1; then compound 2; then compound 4. At a limit, above all of these: compound 3.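

In this assay, 4-fluorophenyl in place of hydrogen on the amide-type nitrogen costs activity, with a 35-fold higher number from compound 1 to compound 4 (1.54 log units; beyond the scatter) on an otherwise unchanged shared core. Going by these compounds alone, the earlier compounds differ from each other only in the core and give no step, so this is the first measured change at this nitrogen, and the hydrogen there now serves as a reference. One step gives a size but no trend for this position, and nothing measured here gives a cause for it.

Going by these compounds, it remains open whether the cost belongs to the ring itself or to its fluorine, which an unsubstituted phenyl group in the same place would help to separate. On these data alone, it is also open whether a methyl group or a short alkyl chain on this nitrogen would keep the number of compound 1.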